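The compounds below may be only part of what the source reports. "The series", "measured", "known", "first", "only" and "open" are said of these compounds alone.

Measured so far in an assay on HEK293 cells for displacement of a labelled ligand from 5-hydroxytryptamine receptor 6 (Homo sapiens), read by radioligand binding, with a stated time of 60 min, tested at 100 nM; on this read-out higher numbers stand for more inhibition at the one concentration tested (going by the name of the read-out) and lower numbers for less inhibition:
compound 1 `CN(C)CCn1c(=O)sc2cc(NS(=O)(=O)c3ccc4ccccc4c3)ccc21` gives 22%;
compound 2 `O=c1sc2cc(NS(=O)(=O)c3ccc4ccccc4c3)ccc2n1CCN1CCCC1` gives 0%;
compound 3 `CN(C)CCn1c(=O)sc2cc(S(=O)(=O)N(C)c3ccccc3)ccc21` gives 5%.

Compound 4 `CN(c1ccccc1)S(=O)(=O)c1ccc2c(c1)sc(=O)n2CCN1CCCC1` has not yet been measured. Compounds 1 and 2 share one core and differ only by pyrrolidin-1-yl in place of dimethylamino on a saturated chain carbon, two bonds along the chain from an aromatic nitrogen; this single change gave a number 22 percentage points lower from compound 1 to compound 2 (beyond the scatter). Compound 3 carries a different core, and the difference between the two cores is not broken down here. Compound 4 arises from compound 3 by the same change, (pyrrolidin-1-yl in place of dimethylamino on a saturated chain carbon, two bonds along the chain from an aromatic nitrogen), at the same place. Because the earlier change gave a number 22 percentage points lower from compound 1 to compound 2 (beyond the scatter), a downward step is expected again, a number 5 percentage points lower from compound 3 to compound 4 (within the scatter), though compound 3 already sits near the bottom of the scale, so the read-out cannot fall far beneath it. Compound 4 is therefore expected to give 0%, most likely between -8% and 8%.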

Compound 4, a percentage reported as inhibition, at one concentration (the size of the read-out at that concentration, not a potency): 10%
Compound 4: the middle estimate sits 10 percentage points below what was measured; the whole stated range lies below it.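

In this assay the move from dimethylamino to pyrrolidin-1-yl gives a number 5 percentage points higher from compound 3 to compound 4 (within the scatter) so the earlier drop does not repeat on this second core. Among the compounds shown here, with only two pairs, this shows that the result of this change on one core cannot simply be carried to the other, but it does not show which part of the cores is responsible or how the change behaves on any further core. Set side by side, the two steps differ: the same change on two cores in this assay, a number 22 percentage points lower (beyond the scatter) from compound 1 to compound 2 and a number 5 percentage points higher (within the scatter) from compound 3 to compound 4, 27 percentage points apart, beyond the scatter of two such steps

From the compounds shown here alone, it remains open how a piperidin-1-yl or morpholin-4-yl group would behave in the same place on each core. A longer chain between the aromatic nitrogen and the amine is also left open.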